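The source may hold more compounds than are shown below. What is called first, only, known or untested is meant among the compounds shown, and "the series" means these compounds.

Compound 1 `NC1=NC2(CCSCC2)N(OCCCOc2cccc(Cl)c2)C(N)=N1` is one of three measured entries in a series built on a shared core carrying a propyloxy link to a chlorinated phenyl ether. In a functional assay on HepG2 cells (Homo sapiens) for antiproliferative activity, read by MTT assay, with a stated time of 72 h (a higher number here means a weaker inhibitor, a lower number a stronger inhibitor), compound 1 gives 90 nM, the lowest of the two numbers available. For the measured compounds named here, compound 3 `NC1=NC2(CCOCC2)N(OCCCOc2cccc(Cl)c2Cl)C(N)=N1` gives 330 nM in this assay, a higher number that lies beyond the scatter of the method; compound 3 differs from compound 1 in more than one place, so the two values show only that compound 3 is the weaker inhibitor of the pair. Compound 2 `NC1=NC2(CCOCC2)N(OCCCOc2ccc(Cl)cc2)C(N)=N1` has no result in this assay: it is "not determined" (no result reported).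

The next compound, compound 4 `NC1=NC2(CCSCC2)N(OCCCOc2cc(Cl)c(Cl)cc2Cl)C(N)=N1`, keeps the core and link of compound 1 and changes the aryl group only: 2,4,5-trichlorophenyl in place of 3-chlorophenyl on an oxygen on a saturated carbon. Going by the values given here, no step between measured compounds isolates this kind of change, so the expectation rests on the general picture: the more heavily chlorinated phenyl ether of compound 3 sits at a higher number than compound 1, but with other differences in play. A modest move upward, towards a weaker inhibitor, is expected for compound 4, and the step from compound 1 is expected to be a 2.2-fold higher number from compound 1 to compound 4 (0.35 log units; beyond the scatter). In this assay compound 4 is expected to give about 200 nM, within a range from 60 nM to 700 nM.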

Compound 4, half-maximal inhibitory concentration: > 100000 nM
Compound 4: a limit, no number; the forecaster's own chance of this, stated with the estimate: 5%; middle value at least 500-fold (2.69 log units) from the limit.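

In this assay, replacing 3-chlorophenyl with 2,4,5-trichlorophenyl on an oxygen on a saturated carbon, with the core and link held constant, gives an at least 1100-fold higher number from compound 1 to compound 4 (3.04 log units; beyond the scatter), so the aryl group at this position can by itself decide whether the series shows measurable activity. Compound 4 reads > 100000 nM, which is a limit of the assay and not a number, so the step gives only a bound on the size of the change: the limit of > 100000 nM in this assay, at which 1 of the 4 values shown sits.

Before this step, no pair in the series differed in one place, so the aryl group had no isolated reading; it now has one, and the loss arises within the chlorophenyl ethers alone.

From the compounds shown here alone, the step changes the number of chlorines and their pattern together, so it remains open which of the added chlorines carries the loss, or whether it takes all of them. Also open, going by these compounds, is whether unsubstituted phenyl, or a phenyl ring carrying a methoxy group or an amine, on the core of compound 1 would stay close to compound 1 at 90 nM or fall away as compound 4 does.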